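Methylselanyl for methylsulfanyl on a shared quinazoline-free core

This account rests on a few compounds, and the source may have more. Where it says the series, first, only, none or still open, it means among the compounds named here.

Measured so far in a functional assay on MCF7 cells (Homo sapiens) for cytotoxicity, read by MTT assay, with a stated time of 72 h; on this read-out higher numbers stand for weaker inhibition of growth and lower numbers for stronger inhibition of growth:
- compound 1, `CCCCC[Se]c1nc(NCc2ccc(SC)cc2)c2ccccc2n1`: 34700 nM
- compound 2, `CSc1ccc(CNc2nc([SeH])nc3ccccc23)cc1`: 48100 nM
- compound 3, `CSc1ccc(CNc2nc(SC)nc3ccccc23)cc1`: 47300 nM

Compound 3 sits second highest of the three numbers; its nearest neighbour is compound 2, and the step of a 1.0-fold lower number from compound 2 to compound 3 (0.01 log units; within the scatter) lies within the scatter. The step of a 1.4-fold higher number from compound 1 to compound 3 (0.13 log units; within the scatter) also lies within the scatter, as does a 1.4-fold higher number from compound 1 to compound 2 (0.14 log units; within the scatter). So all three measured compounds give numbers that cannot be told apart in this assay.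

Compound 4, `CSc1ccc(CNc2nc([Se]C)nc3ccccc23)cc1`, arises from compound 3 by a group of 2 heavy atoms (1 carbon, 1 selenium; no ring) in place of a group of 2 heavy atoms (1 carbon, 1 sulfur; no ring), on an aromatic carbon. The two steps that bear on this change are the ones that swap sulfur-bearing and selenium-bearing groups at the same place on the shared core: a 1.0-fold lower number from compound 2 to compound 3 (0.01 log units; within the scatter) and a 1.4-fold higher number from compound 1 to compound 3 (0.13 log units; within the scatter), both within the scatter. The expectation is therefore a step of a 1.1-fold lower number from compound 3 to compound 4 (0.05 log units; within the scatter), with no change beyond the scatter in either direction. For compound 4 the estimated value in this assay is 42000 nM, with a likely range from 20000 nM to 90000 nM.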

Compound 4, concentration for 50% growth inhibition: 54100 nM
The estimate for compound 4 lay 1.3-fold (0.11 log units) below the measured number; the range from low to high includes it.
By their numbers in this assay, from the lowest: compounds 1, 3, 2 and 4 (each within the scatter of the next).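

In this assay, going by these compounds alone, replacing sulfur with selenium in the methylsulfanyl group, on the aromatic carbon between two ring nitrogen atoms, gives a 1.1-fold higher number from compound 3 to compound 4 (0.06 log units; within the scatter) and is the first direct test of this one-atom swap with the methyl kept in place. Methyl in place of hydrogen on the selenium gives a 1.1-fold higher number from compound 2 to compound 4 (0.05 log units; within the scatter) and cutting the pentyl chain of compound 1 back to methyl gives a 1.6-fold higher number from compound 1 to compound 4 (0.19 log units; within the scatter) so hydrogen, methyl and pentyl on selenium cannot be told apart here. Nothing available explains why these numbers stay so close.

From the compounds shown here alone, whether an amine or a carboxylic acid at this place, or a chain longer than pentyl on the selenium, would move the number beyond the scatter remains open. So does the effect of the same selenium swap in the methylsulfanyl group that all four compounds carry elsewhere.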